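Three measured compounds, one ring swap, one expectation

This account rests on a few compounds, and the source may have more. Where it says the series, first, only, none or still open, it means among the compounds named here.

Compound 1 `CC1(C)CC12NC(=O)N(NC(=O)c1ccc(Cl)cc1)C2=O` gives 300 mg/kg in a functional assay on the whole organism (Hindlimb) for inhibition, with Mus musculus as the target, with a stated time of 4 h; on this read-out higher numbers stand for an effect only at larger amounts of compound and lower numbers for an effect already at smaller amounts.
Compound 2 `CC1(C)CC12NC(=O)N(NC(=O)c1ccc(F)cc1)C2=O` gives 300 mg/kg in this assay.
Compound 3 `COc1ccc(C(=O)NN2C(=O)NC3(CC3(C)C)C2=O)cc1OC` gives 300 mg/kg in this assay.

Compound 1 stands level with compounds 2 and 3: all three show the same number, so on these values none of them is set apart from the others. Compound 4 `CC1(C)CC12NC(=O)N(NC(=O)c1cccnc1)C2=O` has not yet been measured. It differs from compound 1 in one place, (pyridin-3-yl in place of 4-chlorophenyl on a carbonyl carbon). Within the data shown here, the only measured step that alters the aromatic part of the amide is the one with fluoro in place of chloro on an aromatic carbon: no change at the digits printed from compound 1 to compound 2 (within the scatter). Compound 3, with a third variant of that aromatic part, shows the same value as compound 1 as well. Three different aromatic groups on the carbonyl carbon thus give one and the same number. Putting pyridin-3-yl there is a bigger alteration than exchanging one halogen for another, so the precedent is thin, but nothing in these values points in either direction. The step from compound 1 to compound 4 is therefore expected to be no change at the digits printed from compound 1 to compound 4 (within the scatter), within the scatter. Compound 4 is estimated at 300 mg/kg, with a range from 150 mg/kg to 600 mg/kg.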

Compound 4, minimum effective dose: 300 mg/kg
Beside the measured number, compound 4's estimate shows no gap at the digits printed; measured number inside the range.
By their numbers in this assay, from the lowest: compounds 1, 2, 3 and 4 (each within the scatter of the next).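

In this assay, the earlier step only exchanged one halogen for another, whereas this change replaces the whole 4-chlorophenyl group on the carbonyl carbon with pyridin-3-yl, which has a ring nitrogen and one hydrogen-bond acceptor where the 4-chlorophenyl group has none. The result is no change at the digits printed from compound 1 to compound 4 (within the scatter) and no change at the digits printed from compound 2 to compound 4 (within the scatter), so at this place the halogen can be lost and a ring carbon exchanged for nitrogen without any visible effect on the read-out. Nothing available explains why the number holds.

Every compound shown still carries an aromatic ring on this carbonyl carbon, so it remains open whether a saturated cyclohexyl group or a plain butyl chain would give the same value. Also open, going by these compounds, is whether a phenyl ring bearing an amine or a carboxylic acid would move the number at all.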